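Dichlorobenzyl analogue in the nitro-trifluoromethylphenyl triazole series

The source may hold more compounds than are shown below. What is called first, only, known or untested is meant among the compounds shown, and "the series" means these compounds.

Measured compounds:
Compound 1 `COc1ccc(CSc2nnc(-c3cc([N+](=O)[O-])cc(C(F)(F)F)c3)n2Cc2ccccc2)cc1`: > 30000 nM
Compound 2 `O=[N+]([O-])c1cc(-c2nnc(SCc3ccc(Cl)cc3)n2Cc2ccccc2)cc(C(F)(F)F)c1`: > 30000 nM

In an ADME assay on A-431 cells (Homo sapiens) for cytotoxicity, with a stated time of 48 h (a lower number here means a stronger inhibitor, a higher number a weaker inhibitor), compound 1 gives > 30000 nM, which is a limit rather than a number. Compound 2 gives > 30000 nM, also a limit. The step that the two limits leave unreadable from compound 1 to compound 2 is unreadable, both values sitting at the limit of > 30000 nM in this assay, at which 2 of the 2 values shown sit. Compound 3 `O=[N+]([O-])c1cc(-c2nnc(SCc3ccc(Cl)c(Cl)c3)n2Cc2ccccc2)cc(C(F)(F)F)c1` differs from compound 2 by chloro in place of hydrogen on an aromatic carbon. Going by the values given here, no measured step gives a readable size or direction for this change, so no shift beyond the scatter is expected. Compound 3 is expected to remain at the limit, with the expected step that the limit leaves unreadable from compound 2 to compound 3, estimate 40000 nM, range 15000 nM to 100000 nM.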

Compound 3, half-maximal inhibitory concentration: > 30000 nM
Compound 3 was reported as a limit (the forecaster's own chance of this, stated with the estimate: 80%); the middle value lies beyond the limit too.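

The steps among compound 1, compound 2 and compound 3 cannot be read, so no new step follows from compound 3: the limit of > 30000 nM in this assay, at which 3 of the 3 values shown sit.

Going by these compounds, whether methoxy, chloro or a second chloro on the benzyl group changes the read-out in this assay stays open.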